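This account rests on a few compounds, and the source may have more. Where it says the series, first, only, none or still open, it means among the compounds named here.

Series notes. In a functional assay on T-24 cells (Homo sapiens) for cytotoxicity, read by neutral red uptake, with a stated time of 72 h (on this read-out higher numbers stand for weaker inhibition and lower numbers for stronger inhibition), compound 1 `CCNc1nc(SCC)nc2ncccc12` gives 20100 nM. Compound 2 `CCCCNc1nc(SCC)nc2ncccc12` gives 20900 nM in this assay, and the step of a 1.0-fold higher number from compound 1 to compound 2 (0.02 log units; within the scatter) lies within the scatter. Compound 3 `CCCCCNc1nc(SCC)nc2ncccc12` gives 4300 nM in this assay, the lowest of the three numbers, with the steps of a 4.7-fold lower number from compound 1 to compound 3 (0.67 log units; beyond the scatter) and a 4.9-fold lower number from compound 2 to compound 3 (0.69 log units; beyond the scatter) both beyond the scatter.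

The next compound is compound 4 `CCCCCCNc1nc(SCC)nc2ncccc12`, to be measured in this assay. Its change from compound 3 is methyl in place of hydrogen on a saturated chain carbon, five bonds along the chain from a nitrogen on an aromatic ring, a further lengthening of the chain on the ring nitrogen. The step that bears most directly on it is a 4.9-fold lower number from compound 2 to compound 3 (0.69 log units; beyond the scatter), the same addition of a methyl, there placed four bonds along the chain from the ring nitrogen. The step of a 1.0-fold higher number from compound 1 to compound 2 (0.02 log units; within the scatter) shows that an earlier extension of the same chain gave nothing beyond the scatter, so the two measured extensions disagree in size, and the pattern rests on compound 3 alone. Among the compounds with values here, with only one step that matches in kind, a smaller lowering than that step is expected for compound 4 in this assay, with a plain possibility of no change beyond the scatter. Compound 4 is therefore expected at 2500 nM in this assay, within 900 nM to 7000 nM, corresponding to an expected step of a 1.7-fold lower number from compound 3 to compound 4 (0.24 log units; within the scatter).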

Compound 4, half-maximal inhibitory concentration: 5900 nM
For compound 4 the middle estimate is 2.4-fold (0.37 log units) below the measured one, and the stated range covers the measured number.
By their numbers in this assay, from the lowest: compounds 3 and 4 (each within the scatter of the next); then compounds 1 and 2 (each within the scatter of the next).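

In this assay, within the data shown here, adding a methyl on a saturated chain carbon, five bonds along the chain from a nitrogen on an aromatic ring, does not extend the earlier lowering: a 1.4-fold higher number from compound 3 to compound 4 (0.14 log units; within the scatter) is the first reading at this position. The lower level first seen at compound 3 nevertheless holds with the longer chain of compound 4, as both a 3.5-fold lower number from compound 2 to compound 4 (0.55 log units; beyond the scatter) and a 3.4-fold lower number from compound 1 to compound 4 (0.53 log units; beyond the scatter) show, so it no longer rests on a single compound. Across these four compounds, the numbers form two levels instead of a steady fall with chain length, with compounds 1 and 2 at one level and compounds 3 and 4 at the other, and the step from compound 1 to compound 2 goes against any steady fall.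

On these data alone, whether a longer chain, a branched chain or a chain ending in an amine or a carboxylic acid would keep this level or return to that of compounds 1 and 2 remains open. Also open, as far as these compounds go, is whether the same two levels would appear if the shared core carried something other than its present sulfur-linked ethyl group. Nothing at hand accounts for the difference between the two levels.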